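Amine side chain and human microsomal clearance

The source may report more compounds than this note shows. Statements on the series, on what has been measured and on what is new or still open speak of the compounds shown alone.

Measured so far:
- compound 1 `CN(C)CCN1CCN(c2ccc(Cn3c(=O)[nH]c4c(N)nc(C(F)(F)F)cc43)cn2)CC1`: in an in vitro ADME assay on microsomes from liver (Homo sapiens) for pharmacokinetics (on this read-out higher numbers stand for fast clearance and lower numbers for slow clearance), compound 1 gives < 8 mL.min-1.g-1, which is a limit of the assay and not a number.
- compound 2 `Nc1nc(C(F)(F)F)cc2c1[nH]c(=O)n2Cc1ccc(NCCN2CCCCC2)nc1`: in this assay compound 2 gives 13 mL.min-1.g-1.

For the measured compounds named here, compound 2 holds the only plain number in this assay; the other value shown is the limit of < 8 mL.min-1.g-1 in this assay, at which 1 of the 2 values shown sits. Going by the values given here, the single measured step, an at least 1.6-fold higher number from compound 1 to compound 2 (0.21 log units; that floor lies within the scatter), points toward faster clearance, but its floor lies within the scatter, so its true size is open.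

Compound 3 `CN1CCN(c2ccc(Cn3c(=O)[nH]c4c(N)nc(C(F)(F)F)cc43)cn2)CC1` is not yet measured. (4-methylpiperazin-1-yl in place of (2-(piperidin-1-yl)ethyl)amino on an aromatic carbon). Among the compounds with values here, the change largely reverses the one measured step, since compound 3 again carries a piperazine on that aromatic carbon, as compound 1 does, though with a shorter chain on the piperazine.

Within the data shown here, the step of an at least 1.6-fold higher number from compound 1 to compound 2 (0.21 log units; that floor lies within the scatter) is therefore the only guide, and the step of a 1.4-fold lower number from compound 2 to compound 3 (0.16 log units; within the scatter) is expected to run the other way, toward slower clearance, at a size not clearly beyond the scatter. Compound 3 is expected to give 9 mL.min-1.g-1, in a range from 5 mL.min-1.g-1 to 16 mL.min-1.g-1, with a fair chance that only a limit is reported.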

Compound 3, intrinsic clearance in microsomes: 30 mL.min-1.g-1
Compound 3: middle estimate off by 3.3-fold (0.52 log units), on the low side; the measured number lies above the stated range.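

Placing 4-methylpiperazin-1-yl in place of (2-(piperidin-1-yl)ethyl)amino on the aromatic carbon next to the ring nitrogen gives a 2.3-fold higher number from compound 2 to compound 3 (0.36 log units; beyond the scatter) in this assay and so shows that a piperazine at this position does not by itself go with the lower number. Within the piperazine pair, hydrogen in place of (dimethylamino)methyl on the saturated chain carbon gives an at least 3.7-fold higher number from compound 1 to compound 3 (0.57 log units; beyond the scatter) and places much of the difference in the chain on the piperazine, with compound 1 going against any reading based on the ring alone. The size of that step remains a floor, since the value of compound 1 is a limit of the assay and not a number: the limit of < 8 mL.min-1.g-1 in this assay, at which 1 of the 3 values shown sits.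

The compounds shown do not separate the contributions of the amino link and the piperidine within the group that leaves compound 2, so a (2-(morpholin-4-yl)ethyl)amino or a piperidine joined directly to the aromatic carbon would bear on that. From the compounds shown here alone, whether the number follows chain length on the piperazine also stays open, and 4-ethylpiperazin-1-yl and 4-(2-methoxyethyl)piperazin-1-yl would test this between the two piperazine compounds.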